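The source may hold more compounds than are shown below. What is called first, only, known or untested is meant among the compounds shown, and "the series" means these compounds.

Among the three compounds measured so far, compound 3 `C#CC(C)OC(=O)c1ccc(C(CC)(CC)c2ccc(OCC(O)C(C)(C)C)c(C)c2)n1CC` stands second highest: in an assay on HL-60 cells for agonist activity at vitamin D3 receptor (Homo sapiens), read by microscopy, with a stated time of 96 h (on this read-out higher numbers stand for an effect only at larger amounts of compound and lower numbers for an effect already at smaller amounts), compound 3 gives 200 nM. Among the measured compounds shown here, its nearest neighbour is compound 1 `CCOC(=O)CN(C)C(=O)c1ccc(C(CC)(CC)c2ccc(OCC(O)C(C)(C)C)c(C)c2)n1CC`, which in this assay gives 210 nM; the only step that lies beyond the scatter separates it from compound 2 `CCn1c(C(=O)NCCCN(C)C)ccc1C(CC)(CC)c1ccc(OCC(O)C(C)(C)C)c(C)c1`, which in this assay gives 37 nM.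

Compound 4 `CCOc1ccc(NC(=O)c2ccc(C(CC)(CC)c3ccc(OCC(O)C(C)(C)C)c(C)c3)n2CC)cc1` differs from compound 3 by (4-ethoxyphenyl)amino in place of (1-methylprop-2-yn-1-yl)oxy on a carbonyl carbon. For the measured compounds named here, two measured steps bear on a change at this carbonyl carbon. Replacing the group there with a (3-(dimethylamino)propyl)amino gave a 5.7-fold lower number from compound 1 to compound 2 (0.75 log units; beyond the scatter), while going from that group to the (1-methylprop-2-yn-1-yl)oxy gave a 5.4-fold higher number from compound 2 to compound 3 (0.73 log units; beyond the scatter); by contrast, a 1.1-fold lower number from compound 1 to compound 3 (0.02 log units; within the scatter) shows that two other groups at this position left the number essentially unchanged. The entering (4-ethoxyphenyl)amino resembles neither measured group closely, so only a modest shift is expected, a 1.7-fold lower number from compound 3 to compound 4 (0.22 log units; within the scatter), leaning toward a lower number because of the direction seen in a 5.7-fold lower number from compound 1 to compound 2 (0.75 log units; beyond the scatter). Compound 4 is therefore estimated at 120 nM, with a range from 40 nM to 400 nM.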

Compound 4, half-maximal effective concentration: 630 nM
For compound 4 the middle estimate is 5.3-fold (0.72 log units) below the measured one, and the stated range ends below it.
By their numbers in this assay, from the lowest: compound 2; then compounds 3 and 1 (each within the scatter of the next); then compound 4.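

In this assay, the (4-ethoxyphenyl)amino took the number past the level that compounds 1 and 3 had shared, with a 3.2-fold higher number from compound 3 to compound 4 (0.50 log units; beyond the scatter) and a 3.0-fold higher number from compound 1 to compound 4 (0.48 log units; beyond the scatter), so this carbonyl carbon can carry groups that raise the number beyond that level as well as one that lowers it. Among the compounds shown here, the largest step so far lies on the amide-type nitrogen, where 4-ethoxyphenyl in place of 3-(dimethylamino)propyl gave a 17-fold higher number from compound 2 to compound 4 (1.23 log units; beyond the scatter), so the group on that nitrogen alone can produce a large change. No available evidence accounts for these shifts.

As far as these compounds go, it remains open whether the higher number goes with the aromatic ring or with its ethoxy group, which a plain phenylamino would help separate. From the compounds shown here alone, it is also open whether a shorter amine chain, such as 2-(dimethylamino)ethylamino, would keep the lower number of compound 2.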